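Cyclopropyl for Cyclobutyl on a Piperazine Nitrogen

A few compounds are considered here, and "the series" means these few. Any claim that something is new, unique, unknown or untested is made for them only; others in the source may bear on it.

Measured compounds:
compound 1, `CCN1CCN(c2cccc3c2CN([C@H](CCCNC(=O)c2cccs2)c2ccc(OC)c(OC)c2)C3=O)CC1` — 7 nM
compound 2, `COc1ccc([C@@H](CCCN(C)S(=O)(=O)c2cccs2)N2Cc3c(cccc3N3CCN(C4CCC4)CC3)C2=O)cc1OC` — 4 nM

Of the compounds shown here, two have been measured in a functional assay on CHO-K1 cells for antagonist activity at Urotensin-2 receptor (Rattus norvegicus), read by FLIPR and calcium flux, with a stated time of 1 h; on this read-out lower numbers stand for stronger inhibition and higher numbers for weaker inhibition. Compound 1 gives 7 nM. Compound 2 gives 4 nM. Compound 2 holds the lowest of the two numbers, but its nearest neighbour, compound 1, sits within the scatter of repeated measurements, so the two cannot be ordered against each other.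

Compound 3, `COc1ccc([C@@H](CCCN(C)S(=O)(=O)c2cccs2)N2Cc3c(cccc3N3CCN(C4CC4)CC3)C2=O)cc1OC`, has not yet been measured. It differs from compound 2 in one place: cyclopropyl in place of cyclobutyl on an amine nitrogen in a ring. For the measured compounds named here, no pair of measured compounds separated by a single change is available, so the size of this step cannot be read from the data; it has to be expected from the smallness of the change alone. The author expects the step of a 1.3-fold higher number from compound 2 to compound 3 (0.10 log units; within the scatter) in this assay to stay within the scatter, in no particular direction. Compound 3 is estimated at 5 nM, within a range from 2 nM to 15 nM.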

Compound 3, half-maximal inhibitory concentration: 13 nM
Compound 3: the middle estimate sits 2.6-fold (0.41 log units) below what was measured, and the stated range covers the measured number.
By their numbers in this assay, from the lowest: compounds 2, 1 and 3 (each within the scatter of the next, the first and the last beyond it).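

In this assay, going from a four-membered to a three-membered carbon ring on the amine nitrogen of the piperazine gives a 3.3-fold higher number from compound 2 to compound 3 (0.51 log units; beyond the scatter). For the compounds shown here, this is the first single-change step, and it shows that the read-out responds to even this small a change in the group at this position, although the step is modest. No measurement shown accounts for this step.

Going by these compounds, one step cannot show how the read-out follows ring size at this nitrogen, so it remains open how a cyclopentyl ring, an isopropyl group or a plain hydrogen there would compare with cyclobutyl. On these data alone, it is also open whether the same step would appear with the thiophene amide chain of compound 1 in place of the sulfonamide chain of compound 2.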